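This account rests on a few compounds, and the source may have more. Where it says the series, first, only, none or still open, it means among the compounds named here.

In a functional assay on CCRF-CEM cells (Homo sapiens) for antiproliferative activity, read by trypan blue exclusion, with a stated time of 72 h (on this read-out lower numbers stand for stronger inhibition and higher numbers for weaker inhibition), compound 1 `Cc1ccc(NC(=O)C(C)Br)cc1C(=O)NC(N)=O` reads > 20000 nM, which is a limit of the assay and not a number. Within the data shown here, compound 2 `Cc1ccc(NC(=O)CBr)cc1C(=O)NC(N)=O` gives 4760 nM, the only exact number so far. Compound 3 `Cc1ccc(NC(=O)CI)cc1C(=O)NC(N)=O` differs from it by iodo in place of bromo on a saturated chain carbon bound to a carbonyl carbon, a swap of halogen on a saturated chain carbon bound to a carbonyl carbon. Among the measured compounds shown here, the only measured step, an at least 4.2-fold lower number from compound 1 to compound 2 (0.62 log units; beyond the scatter), changed that same carbon, putting hydrogen in place of methyl, and left the bromo group in place. It shows that this carbon can matter, but it gives no size for a halogen swap. The expected change is therefore small, an estimated 1.4-fold lower number from compound 2 to compound 3 (0.13 log units; within the scatter). For compound 3 the estimated value is 3500 nM, with an expected range from 1200 nM to 10000 nM.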

Compound 3, half-maximal inhibitory concentration: 20000 nM
The estimate for compound 3 lay 5.7-fold (0.76 log units) below the measured number; measured number outside the range, above it.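

In this assay, the halogen on this saturated chain carbon matters in its own right: iodo in place of bromo gives a 4.2-fold higher number from compound 2 to compound 3 (0.62 log units; beyond the scatter). Until now, only the swap of methyl for hydrogen on this carbon had shown an effect, and here the inhibition is weaker with iodo than with bromo. Iodomethyl in place of 1-bromoethyl on a carbonyl carbon gives a number no higher from compound 1 to compound 3 (the limit leaves the size open). The size of this step cannot be read, because compound 1 carries a limit and not a number: the limit of > 20000 nM in this assay, at which 1 of the 3 values shown sits.

The compounds shown leave open how chloro, fluoro or an amine on this carbon would read. They also leave open whether a 1-iodoethyl group would follow the 1-bromoethyl group.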